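The source may hold more compounds than are shown below. What is called first, only, known or untested is meant among the compounds shown, and "the series" means these compounds.

Of the compounds shown here, two have been measured in an assay on HEK293 cells for agonist activity at transient receptor potential cation channel subfamily M member 8 (Homo sapiens), read by fluorescence and calcium flux, with a stated time of 15 min; a higher number here means that more compound is needed for the effect, a lower number that less compound is needed. Compound 1 `CCN(Cc1cccs1)C(=O)c1cc2cc(C)ccc2o1` gives 120 nM. Compound 2 `Cc1ccc(OCC(=O)N(Cc2cccs2)c2ccnn2C)cc1` gives 422 nM, the higher of the two numbers, so more of it is needed than of compound 1, and that gap lies beyond the usual scatter. Compound 3 `Cc1ccc(OCC(=O)N(Cc2cccs2)c2ccccn2)cc1` has not been measured; it differs from compound 2 in a single place: pyridin-2-yl in place of 1-methyl-1H-pyrazol-5-yl on an amide-type nitrogen. For the measured compounds named here, no measured pair shows this exchange, so nothing here sets its size. The step of a 1.1-fold lower number from compound 2 to compound 3 (0.02 log units; within the scatter) is expected to stay within the scatter. Compound 3 is estimated at 400 nM, most likely between 150 nM and 1200 nM.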

Compound 3, half-maximal effective concentration: 200 nM
Compound 3: the middle estimate sits 2.0-fold (0.30 log units) above what was measured; measured number inside the range.
By their numbers in this assay, from the lowest: compounds 1 and 3 (each within the scatter of the next); then compound 2.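

In this assay, for the compounds shown here, pyridin-2-yl in place of 1-methyl-1H-pyrazol-5-yl on the amide-type nitrogen gives a 2.1-fold lower number from compound 2 to compound 3 (0.32 log units; beyond the scatter) and so shows, for the first time, that this position responds to a single exchange. The step is modest, yet one aromatic ring replacing another with the same count of heavy atoms is enough to move the number beyond the scatter. No measurement here explains the change. Open, on these data alone, is whether a cyclohexyl ring on that nitrogen keeps the effect, and how a phenyl ring there compares with pyridin-2-yl.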